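From 3-fluorophenyl to 4-fluorophenyl in a weak compound

This account rests on a few compounds, and the source may have more. Where it says the series, first, only, none or still open, it means among the compounds named here.

Compound 1 (`COc1cc(-c2ncnn2-c2cccc(F)c2)cc(OC)c1OC`) is the reference for this step. In a functional assay on K562 cells (Homo sapiens) for antiproliferative activity, read by MTT assay, with a stated time of 72 h (on this read-out higher numbers stand for weaker inhibition and lower numbers for stronger inhibition), compound 1 gives > 10000 nM as a limit of the assay and not as a number. Compound 2 (`CCOc1ccc(-c2ncnn2-c2cc(OC)c(OC)c(OC)c2)cc1Cl`) gives 20 nM in this assay and so shows far stronger inhibition on these two values. Compound 3 (`COc1cc(-c2ncnn2-c2ccc(F)cc2)cc(OC)c1OC`) has 4-fluorophenyl in place of 3-fluorophenyl on an aromatic nitrogen and the same atoms as compound 1, joined differently. Going by the values given here, no measured step covers such a change, and compound 2 differs from compound 3 in more than one place. The estimated step of an at least 1.4-fold lower number from compound 1 to compound 3 (0.15 log units; that floor lies within the scatter) is expected to be small and towards stronger inhibition, and a second limit reading remains likely. For compound 3 the estimate is 7000 nM with an expected range of 1500 nM to 30000 nM in this assay for now.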

Compound 3, half-maximal inhibitory concentration: > 10000 nM
Compound 3 gave a limit, no number (the forecaster's own chance of this, stated with the estimate: 55%); at least 1.4-fold (0.15 log units) between middle value and limit.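

No step from compound 1 to compound 3 can be read in this assay, since both compounds sit at the same limit of the assay: the limit of > 10000 nM in this assay, at which 2 of the 3 values shown sit.

The compounds shown leave open whether 4-fluorophenyl and 3-fluorophenyl on an aromatic nitrogen differ at all in inhibition, and in which direction.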